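This account rests on a few compounds, and the source may have more. Where it says the series, first, only, none or still open, it means among the compounds named here.

In a functional assay on A-375 cells (Homo sapiens) for antiproliferative activity (on this read-out lower numbers stand for stronger inhibition and higher numbers for weaker inhibition), compound 1 (`O=C(Nc1ccc(-c2cscn2)cc1)[C@H]1CCCN(Cc2ccc(F)c(F)c2)C1`) gives 190 nM and compound 2 (`O=C(Nc1ccc(-c2ccccn2)cc1)C1CCCN(Cc2ccc(F)c(F)c2)C1`), with a pyridin-2-yl group, gives 9000 nM. Compound 3 (`O=C(Nc1ccc(-c2c[nH]cn2)cc1)C1CCCN(Cc2ccc(F)c(F)c2)C1`), with a 1H-imidazol-4-yl group in that place, reads > 20000 nM as a limit of the assay and not a number. Compound 3 therefore stands at the limit of > 20000 nM in this assay, at which 1 of the 3 values shown sits, and has no exact place on the scale.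

Compound 4 (`O=C(Nc1ccc(-c2cc[nH]c2)cc1)C1CCCN(Cc2ccc(F)c(F)c2)C1`) has not yet been measured. The change from compound 3 is 1H-pyrrol-3-yl in place of 1H-imidazol-4-yl on an aromatic carbon with 1H-pyrrol-3-yl in place of 1H-imidazol-4-yl on an aromatic carbon of a six-membered aromatic ring of carbon only, para to a large group.

Within the data shown here, one measured step bears on this place and ends at compound 3: it is an at least 2.2-fold higher number from compound 2 to compound 3 (0.34 log units; beyond the scatter) and its full size stays open. Compound 1 and compound 2 are not a clean single step apart, so their values show only how wide the range runs. A step to a lower number is expected in this assay, resting on compound 2 at 9000 nM, which gives a measurable value without the 1H-imidazol-4-yl group. The expected change is an at least 3.3-fold lower number from compound 3 to compound 4 (0.52 log units; beyond the scatter) and its size is only loosely fixed. For compound 4 the estimate is 6000 nM, with an expected range from 1000 nM to 20000 nM.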

Compound 4, half-maximal inhibitory concentration: 1420 nM
Estimate against measurement, compound 4: 4.2-fold (0.63 log units) above, and the stated range covers the measured number.
By their numbers in this assay, from the lowest: compound 1; then compound 4; then compound 2. At a limit, above all of these: compound 3.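

In this assay, placing 1H-pyrrol-3-yl on the aromatic carbon para to a large group, in place of 1H-imidazol-4-yl, gives an at least 14-fold lower number from compound 3 to compound 4 (1.14 log units; beyond the scatter), so a single ring nitrogen exchanged for carbon in the five-membered aromatic ring separates a measurable value from none. For compound 3 the reading is a limit of the assay and not a number, so the step has a lower bound and no exact size: the limit of > 20000 nM in this assay, at which 1 of the 4 values shown sits. Among these compounds, the step of a 6.3-fold lower number from compound 2 to compound 4 (0.80 log units; beyond the scatter) adds what the earlier compounds could not show, namely that a five-membered aromatic ring with a hydrogen-bond donor can stand at this place and give a measurable value, one that lies beyond the scatter from that of the pyridin-2-yl group.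

The compounds shown leave open whether the ring hydrogen-bond donor of 1H-pyrrol-3-yl is needed here, a question that a furan-3-yl or a 1-methyl-1H-pyrrol-3-yl group at the same place would address. They also give no cause for either step, and they leave open how a methyl group or a chlorine atom on the 1H-pyrrol-3-yl ring would read.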